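The source may hold more compounds than are shown below. What is called first, only, known or untested is meant among the compounds shown, and "the series" means these compounds.

In a functional assay on M21 cells (Homo sapiens) for antiproliferative activity, read by sulforhodamine B assay, with a stated time of 48 h (a lower number here means a stronger inhibitor, a higher number a weaker inhibitor), compound 1 `CCN1CCN(c2ccc(S(=O)(=O)Oc3cccc(OC)c3)cc2)C1=O` gives 7000 nM, and compound 2 `CCN1CCN(c2ccc(S(=O)(=O)Oc3cccc(Cl)c3)cc2)C1=O` gives 3900 nM. The step of a 1.8-fold lower number from compound 1 to compound 2 (0.25 log units; within the scatter) leaves compound 2 and compound 1 standing together, since that gap lies within the scatter. Compound 3 `CCCN1CCN(c2ccc(S(=O)(=O)Oc3cccc(Cl)c3)cc2)C1=O` differs from compound 2 by methyl in place of hydrogen on a saturated chain carbon, two bonds along the chain from an amide-type nitrogen in a ring. Among the compounds with values here, the only measured step concerns a substituent on an aromatic carbon, not the chain on the ring nitrogen, so nothing measured bears directly on this change, and no step beyond the scatter is expected in this assay. Compound 3 is therefore estimated at 3500 nM, within 1500 nM to 8500 nM, an expected step of a 1.1-fold lower number from compound 2 to compound 3 (0.05 log units; within the scatter).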

Compound 3, half-maximal inhibitory concentration: 8600 nM
Estimate against measurement, compound 3: 2.5-fold (0.39 log units) below; the whole stated range lies below it.
By their numbers in this assay, from the lowest: compounds 2, 1 and 3 (each within the scatter of the next, the first and the last beyond it).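

Going from ethyl to propyl, methyl in place of hydrogen on a saturated chain carbon, two bonds along the chain from an amide-type nitrogen in a ring, gives a 2.2-fold higher number from compound 2 to compound 3 (0.34 log units; beyond the scatter) in this assay. This is the first change shown at this chain, and it shows that the single added carbon moves the number modestly but beyond the scatter, toward weaker inhibition. Nothing available explains this step. From the compounds shown here alone, whether a butyl chain would raise the number further, or a shorter methyl group lower it, stays open. So does the effect of an amine at the end of this chain.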